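The source may report more compounds than this note shows. Statements on the series, on what has been measured and on what is new or still open speak of the compounds shown alone.

Values in a functional assay on OVCAR-8 cells (Homo sapiens) for inhibition, read by sulforhodamine B assay, with a stated time of 48 h; a higher number here means a weaker inhibitor of growth, a lower number a stronger inhibitor of growth:
- Compound 1 `Cc1ccc(NC(=O)/C=C/c2ccccc2)c(C(N)=O)c1`: 7490 nM
- Compound 2 `NC(=O)c1cc(Br)ccc1NC(=O)/C=C/c1ccccc1`: "not determined" (no result reported)
- Compound 3 `NC(=O)c1cc(I)ccc1NC(=O)/C=C/c1ccccc1`: 1060 nM

Among the measured compounds shown here, compound 3, at 1060 nM, holds the lower of the only two numbers available in this assay. Compound 4 `NC(=O)c1cc(I)ccc1NC(=O)/C=C/c1ccccc1Cl` is the next point: chloro in place of hydrogen on an aromatic carbon, ortho to a large group, so phenyl becomes 2-chlorophenyl (chloro in place of hydrogen on an aromatic carbon).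

For the measured compounds named here, only one measured step exists, a 7.1-fold lower number from compound 1 to compound 3 (0.85 log units; beyond the scatter). It is a modest step, iodo in place of methyl, and it leaves the phenyl untouched. Going by the values given here, it therefore gives no direct guide to this change, and no measured compound carries chloro. With no evidence for a large shift, only a small step is expected in this assay, with a slight lean towards a lower number and the direction uncertain. The expected change is a 1.3-fold lower number from compound 3 to compound 4 (0.12 log units; within the scatter). For compound 4 the estimated value is 800 nM, with an expected range of 250 nM to 2500 nM.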

Compound 4, concentration for 50% growth inhibition: 56000 nM
The estimate for compound 4 lay 70-fold (1.85 log units) below the measured number; the measured number lies above the stated range.
By their numbers in this assay, from the lowest: compound 3; then compound 1; then compound 4.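

In this assay, the phenyl of compound 3 turns out not to be a free position: a single added chloro, ortho to a large group, gives a 53-fold higher number from compound 3 to compound 4 (1.72 log units; beyond the scatter). Among the compounds shown here, this is the first change on this side of the molecule, and it is marked as large, whereas the change on the other ring, a 7.1-fold lower number from compound 1 to compound 3 (0.85 log units; beyond the scatter), is marked as modest. Nothing at hand accounts for the size of this step, so its origin stays unassigned.

From the compounds shown here alone, whether the loss belongs to chloro itself or to any group at this place remains open, as a fluoro, methoxy or amine in place of the chloro would be needed to tell. Also open, going by these compounds, is how chloro behaves elsewhere on the phenyl, and steps involving compound 2 cannot be read.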